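Swapping a Naphthyl Amide for a Tolyl Amide

The compounds below may be only part of what the source reports. "The series", "measured", "known", "first", "only" and "open" are said of these compounds alone.

Compound 1, `Cc1nnc(Sc2cc(NC(=O)c3ccc(Cl)cc3)c3ccccc3c2O)s1`: in a functional assay on MDA-MB-231 cells (Homo sapiens) for antiproliferative activity, read by MTT assay, with a stated time of 48 h (a lower number here means a stronger inhibitor, a higher number a weaker inhibitor), compound 1 reaches only a limit, > 100000 nM.
Compound 2, `O=C(Nc1cc(Sc2ncn[nH]2)c(O)c2ccccc12)c1ccc2ccccc2c1`: in this assay compound 2 gives 45100 nM.

Two compounds share a core and differ in the group on the amide carbonyl and in the small sulfur-linked ring. Among the measured compounds shown here, of the two, compound 2 is the only one with a proper number in this assay; the other value is a limit, and the limit of > 100000 nM in this assay, at which 1 of the 2 values shown sits, shows where that limit sits. For the measured compounds named here, no step between measured compounds is available, so nothing is known yet about how changes on the amide side shift the read-out.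

Compound 3, `Cc1cccc(C(=O)Nc2cc(Sc3ncn[nH]3)c(O)c3ccccc23)c1`, has not been measured. It differs from compound 2 by 3-methylphenyl in place of naphthalen-2-yl on a carbonyl carbon. The expected step is a 1.3-fold higher number from compound 2 to compound 3 (0.12 log units; within the scatter), a shift that would stay within the scatter of this assay, since compound 2 at 45100 nM gives the only anchor and no comparable change has been followed. In this assay compound 3 is therefore estimated at 60000 nM, with a range from 20000 nM to 150000 nM.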

Compound 3, half-maximal inhibitory concentration: > 100000 nM
Compound 3: a limit, no number (the forecaster's own chance of this, stated with the estimate: 35%); at least 1.6-fold (0.22 log units) between middle value and limit.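

Among the compounds shown here, this change gives the first readable step on the amide side in this assay: an at least 2.2-fold higher number from compound 2 to compound 3 (0.34 log units; beyond the scatter). With the shared core and the sulfur-linked ring held the same, the group on the carbonyl carbon clearly affects the read-out, and the smaller 3-methylphenyl, with one aromatic ring of carbon only, does worse here than naphthalen-2-yl, with two. Compound 2 is now the only compound with a proper number, and the printed step is only a minimum, since the value for compound 3 is a limit: the limit of > 100000 nM in this assay, at which 2 of the 3 values shown sit.

One step cannot separate the loss of the second aromatic ring from the presence of the methyl group, and it cannot show how far the read-out moves beyond the limit. The compounds shown also leave open whether an unsubstituted phenyl, a quinoline, a longer alkyl chain or a group carrying an amine on the same carbonyl carbon would give a number nearer to that of compound 2, or one lower still.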